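Thienopyrimidinone series: methyl to amino on the pyridyl ring

A few compounds are considered here, and "the series" means these few. Any claim that something is new, unique, unknown or untested is made for them only; others in the source may bear on it.

Measured so far in an assay on isolated protein for inhibition of Rho-associated protein kinase 2 (Homo sapiens), read by radiometric assay and 33P incorporation, with a stated time of 40 min, in the presence of a further agent that is not named here; a lower number here means a stronger inhibitor, a higher number a weaker inhibitor:
compound 1, `COc1cccc(Cn2cnc3sc(-c4cccnc4)cc3c2=O)c1`: 3480 nM
compound 2, `COc1cccc(Cn2cnc3sc(-c4ccnc(C)c4)cc3c2=O)c1`: 42 nM

Compound 2 stands at the lowest of the two numbers; the next compound, compound 1, lies far above it, the step being an 83-fold lower number from compound 1 to compound 2 (1.92 log units; beyond the scatter). That step concerns the whole pyridyl group, 2-methylpyridin-4-yl in place of pyridin-3-yl.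

Compound 3, `COc1cccc(Cn2cnc3sc(-c4ccnc(N)c4)cc3c2=O)c1`, differs from compound 2 in one place: amino in place of methyl on an aromatic carbon. For the measured compounds named here, no measured pair in this set covers an exchange of methyl for amino on the pyridyl ring, so the only step available, from compound 1 to compound 2, does not bear on it directly; it shows only that the pyridyl substitution pattern moves this assay strongly. With the substitution pattern kept, the expectation for compound 3 is a step of modest size, within or near the scatter, in no firm direction; the estimated step is a 1.1-fold lower number from compound 2 to compound 3 (0.02 log units; within the scatter). Compound 3 is therefore expected to give about 40 nM, in the range 10 nM to 160 nM.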

Compound 3, half-maximal inhibitory concentration: 1 nM
Compound 3: middle estimate off by 40-fold (1.60 log units), on the high side; measured number outside the range, below it.
By their numbers in this assay, from the lowest: compound 3; then compound 2; then compound 1.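

Exchanging methyl for amino on the aromatic carbon next to the ring nitrogen gives a 42-fold lower number from compound 2 to compound 3 (1.62 log units; beyond the scatter) in this assay, so the group at this place, and not only the pyridyl substitution pattern, strongly moves the number, even though each group has just 1 heavy atom. The full change of the pyridyl group now spans a 3500-fold lower number from compound 1 to compound 3 (3.54 log units; beyond the scatter), against an 83-fold lower number from compound 1 to compound 2 (1.92 log units; beyond the scatter) for the methyl-bearing compound, which shows that the earlier step captured only part of the range this end of the molecule can reach. The amino group brings a hydrogen-bond donor and acceptor that methyl does not have, but nothing available connects that count with the size of the step, and no supporting data bear on the reason for it.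

On these data alone, it remains open whether this result is particular to amino or extends to other groups at the same place, such as methylamino, dimethylamino, hydroxyl or fluorine. As far as these compounds go, the methoxy group is also the same in all three compounds, so it is unknown whether the amino step would hold with a hydroxyl or a chlorine in its place.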